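Chlorophenyl for methylphenyl on the shared core

This account rests on a few compounds, and the source may have more. Where it says the series, first, only, none or still open, it means among the compounds named here.

Compound 1 `Cc1cccc(N2CCC(C(=O)Nc3ccc4c(c3)NC(=O)CO4)CC2)c1` gives 490 nM in a functional assay for antagonist activity at transient receptor potential cation channel subfamily V member 1 (Homo sapiens), read by FLIPR and calcium flux (on this read-out lower numbers stand for stronger inhibition and higher numbers for weaker inhibition), the highest of the two numbers recorded there. Compound 3 `O=C(Nc1ccc2c(c1)NC(=O)C(CCO)O2)C1CCN(c2cc(F)c(F)c(F)c2)CC1` gives 5 nM in this assay, a lower number that lies beyond the scatter. For compound 2 `CC(=O)N1CCc2cc(NC(=O)C3CCN(c4cccc(C(F)(F)F)c4)CC3)ccc21` this assay reports only a limit, > 9000 nM, (the limit of > 9000 nM in this assay, at which 1 of the 3 values shown sits).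

Compound 4 `O=C1COc2ccc(NC(=O)C3CCN(c4ccccc4Cl)CC3)cc2N1` has not been measured. It differs from compound 1 in one place: 2-chlorophenyl in place of 3-methylphenyl on an amine nitrogen in a ring. Among the measured compounds shown here, no measured pair shows this change, so its size is uncertain. The author expects a small weakening step from compound 1 to compound 4, a 2.4-fold higher number from compound 1 to compound 4 (0.39 log units; beyond the scatter), not clearly beyond the scatter. Compound 4 is therefore estimated at 1200 nM in this assay, within 300 nM to 5000 nM.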

Compound 4, half-maximal inhibitory concentration: 220 nM
Estimate against measurement, compound 4: 5.5-fold (0.74 log units) above; measured number outside the range, below it.
By their numbers in this assay, from the lowest: compound 3; then compound 4; then compound 1. At a limit, above all of these: compound 2.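

Putting 2-chlorophenyl in place of 3-methylphenyl on the amine nitrogen in the ring gives a 2.2-fold lower number from compound 1 to compound 4 (0.35 log units; beyond the scatter) in this assay, the only step at this position among the compounds shown. Both groups hold the same count of heavy atoms and no hydrogen-bond donors or acceptors, so the read-out at this position responds to a swap that leaves those counts unchanged. Nothing measured here gives a cause for this step.

The change alters both the substituent and its place on the phenyl ring, and the compounds shown do not separate the two. From the compounds shown here alone, how 3-chlorophenyl, 2-methylphenyl or unsubstituted phenyl would read on the same core remains open.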